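A few compounds are considered here, and "the series" means these few. Any claim that something is new, unique, unknown or untested is made for them only; others in the source may bear on it.

Measured in an ADME assay on BAEC cells (Bos taurus) for cytotoxicity, read by MTT assay, with a stated time of 2 days; a lower number here means a stronger inhibitor, a higher number a weaker inhibitor:

Compound 1 `COc1c(Br)cc(C=O)c(O)c1Br`: 806000 nM
Compound 2 `COc1c(Br)cc(CO)c(O)c1Br`: > 16000 nM (a limit)
Compound 3 `COC1=C(Br)C(=O)[C@]2(C=C1Br)CO2`: 161000 nM

In this assay compound 2 is known only by a limit, > 16000 nM, so it has no exact standing. Compound 4 `OCc1cc(Br)cc(Br)c1O` has hydrogen in place of methoxy on an aromatic carbon. Among the compounds with values here, the one measured step, a step that the limit leaves unreadable from compound 1 to compound 2, concerns a different change and gives no size to carry over. Within the data shown here, no measured step therefore bears on this replacement, and no shift beyond the scatter is expected in this assay, in either direction. The expected change is a step that the limit leaves unreadable from compound 2 to compound 4. Compound 4 is estimated at 50000 nM, with an expected range from 12000 nM to 300000 nM.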

Compound 4, half-maximal inhibitory concentration: > 35000 nM
Compound 4 ended at the assay's limit; the forecaster's own chance of this, stated with the estimate: 40%; the middle value is on the limit's open side.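

Within the data shown here, compound 2 and compound 4 are each known only by a limit, and no step between them can be read. The compounds shown leave open how large a shift hydrogen in place of methoxy on an aromatic carbon brings.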